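A few compounds are considered here, and "the series" means these few. Any claim that something is new, unique, unknown or untested is made for them only; others in the source may bear on it.

Measured compounds:
compound 1, `Cc1cc(NC(=O)Cn2nnc(-c3ccc(F)c(F)c3)n2)n(C2CCCCC2)n1`, 116 nM in an assay on HEK293 cells for activation of Kir3.1/Kir3.2 (Homo sapiens), read by thallium flux; a higher number here means that more compound is needed for the effect, a lower number that less compound is needed
compound 2, `COc1cccc(-c2nnn(CC(=O)Nc3cc(C)nn3C3CCCCC3)n2)c1`, 117 nM in this assay

In this assay compound 1 gives 116 nM and compound 2 gives 117 nM. Going by the values given here, compound 2 stands alongside compound 1 on these two numbers: the single step connecting them, a 1.0-fold higher number from compound 1 to compound 2 (0.00 log units; within the scatter), lies within the scatter, so the two compounds cannot be told apart here. That step exchanged one phenyl group carrying halogen atoms for a phenyl group carrying a methoxy group, on the same aromatic carbon of the shared core.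

Compound 3, `Cc1cc(NC(=O)Cn2nnc(-c3ccc(C(F)(F)F)cc3)n2)n(C2CCCCC2)n1`, has not yet been measured in this assay. It differs from compound 2 in one place: 4-(trifluoromethyl)phenyl in place of 3-methoxyphenyl on an aromatic carbon. Among the compounds with values here, the only measured step that bears on this change is a 1.0-fold higher number from compound 1 to compound 2 (0.00 log units; within the scatter), which also swapped the group on this aromatic carbon for a differently substituted phenyl and produced no shift beyond the scatter. On that basis compound 3 is expected to show a 1.1-fold higher number from compound 2 to compound 3 (0.05 log units; within the scatter), that is, no step beyond the scatter. The estimate for compound 3 in this assay is 130 nM, with a range from 50 nM to 350 nM.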

Compound 3, half-maximal effective concentration: 241 nM
Estimate against measurement, compound 3: 1.9-fold (0.27 log units) below; measured number inside the range.
By their numbers in this assay, from the lowest: compounds 1 and 2 (each within the scatter of the next); then compound 3.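

The aromatic carbon of the five-membered ring is not indifferent to which substituted phenyl it carries. In this assay, 4-(trifluoromethyl)phenyl in place of 3-methoxyphenyl gives a 2.1-fold higher number from compound 2 to compound 3 (0.31 log units; beyond the scatter), and the same group in place of 3,4-difluorophenyl gives a 2.1-fold higher number from compound 1 to compound 3 (0.32 log units; beyond the scatter), so the earlier tie between compound 1 and compound 2 does not extend to every substituted phenyl, although both new steps are modest. Nothing available here accounts for this shift.

The names 3-methoxyphenyl and 4-(trifluoromethyl)phenyl differ both in the substituent and in the number that gives its place on the phenyl ring, so these three compounds cannot show whether the shift follows the trifluoromethyl group itself or where it sits. From the compounds shown here alone, it also remains open how this position would respond to a plain phenyl with no substituent, or to a phenyl carrying a nitrile or an amine, and whether any such group would need less compound for the effect than compound 1 and compound 2.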